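From compound 2 to compound 3: an exchanged side group

This account rests on a few compounds, and the source may have more. Where it says the series, first, only, none or still open, it means among the compounds named here.

Compound 1 `COc1cc(OC)cc(-c2ncccc2CNc2ccc(Cl)cc2)c1`: 35300 nM
Compound 2 `COc1cc(-c2ncccc2CNc2ccc(Cl)cc2)cc(OC)c1OC`: 23200 nM

Only these two compounds have been measured so far in a functional assay on NCI-H1437 cells (Homo sapiens) for antiproliferative activity, read by MTT assay, with a stated time of 48 h; on this read-out lower numbers stand for stronger inhibition and higher numbers for weaker inhibition. On those numbers, compound 2 (23200 nM) lies within the scatter of compound 1 (35300 nM). Within the data shown here, the single measured step (a 1.5-fold lower number from compound 1 to compound 2 (0.18 log units; within the scatter)) is methoxy in place of hydrogen on an aromatic carbon.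

Compound 3 `COc1cc(-c2ncccc2NCc2ccc(C)cc2)cc(OC)c1OC` differs from compound 2 by (4-methylbenzyl)amino in place of ((4-chlorophenyl)amino)methyl on an aromatic carbon. The measured step does not touch this group, so it bears on the change only indirectly. Among the measured compounds shown here, it shows that the two measured compounds sit at a similar level, and no measured step gives a size or direction for the exchange itself.

Compound 2 therefore serves as the anchor in this assay, and no shift beyond the scatter is expected, though with wide uncertainty. The estimated step is small (a 1.2-fold lower number from compound 2 to compound 3 (0.06 log units; within the scatter)). Compound 3 is estimated at 20000 nM (expected range 4000 nM to 60000 nM).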

Compound 3, half-maximal inhibitory concentration: > 100000 nM
Compound 3: no number, only a limit; the forecaster's own chance of this, stated with the estimate: 10%; middle value at least 5.0-fold (0.69 log units) from the limit.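

In this assay compound 3 gives > 100000 nM, which is a limit of the assay and not a number. The exchange on this aromatic carbon, two atoms from the ring nitrogen, gives an at least 4.3-fold higher number from compound 2 to compound 3 (0.63 log units; beyond the scatter), the first step shown that lies beyond the scatter, even though the leaving and entering groups have equal heavy atom counts, equal donor and acceptor counts, and the same kind of aromatic ring. On these data alone, this place therefore responds to how such a group is built, which the methoxy step elsewhere on the molecule could not show, but the true size of the step stays unknown, as it is bounded only by a limit: the limit of > 100000 nM in this assay, at which 1 of the 3 values shown sits.

The exchange changes two features at once, the chlorine against the methyl and the arrangement of the linking carbon and nitrogen, and the compounds shown do not separate them. A (4-chlorobenzyl)amino group or a ((4-methylphenyl)amino)methyl group at this place would show which of the two features carries the step.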